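Sulfonyl substituent and cytotoxicity: compound 2 to compound 3

The compounds below may be only part of what the source reports. "The series", "measured", "known", "first", "only" and "open" are said of these compounds alone.

Compound 2 `NS(=O)(=O)c1cccc(-c2ccc3nccc(-c4ccncc4)c3n2)c1` gives 2000 nM in an ADME assay on CHO cells (Cricetulus griseus) for cytotoxicity, read by MTT assay (a lower number here means a stronger inhibitor, a higher number a weaker inhibitor), the lowest of the two measured values; compound 1 `O=S(=O)(CCO)c1cccc(-c2ccc3nccc(-c4ccncc4)c3n2)c1` gives 26000 nM. Within the data shown here, the only measured step on this sulfonyl sulfur, a 13-fold lower number from compound 1 to compound 2 (1.11 log units; beyond the scatter), was large. Compound 3 `O=S(=O)(c1cccc(-c2ccc3nccc(-c4ccncc4)c3n2)c1)N1CC[C@H](O)C1` differs from compound 2 by 3-hydroxypyrrolidin-1-yl in place of amino on a sulfonyl sulfur. That step again exchanges the group on the sulfonyl sulfur, and the entering group carries a hydroxyl as the leaving group of compound 1 did, so a partial return toward the number of compound 1 is expected: a 4.0-fold higher number from compound 2 to compound 3 (0.60 log units; beyond the scatter). Compound 3 is therefore estimated at 8000 nM, expected between 2500 nM and 26000 nM.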

Compound 3, half-maximal inhibitory concentration: 9000 nM
The estimate for compound 3 lay 1.1-fold (0.05 log units) below the measured number; the range from low to high includes it.
By their numbers in this assay, from the lowest: compound 2; then compound 3; then compound 1.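

Notes on the sulfonyl sulfur: the step of a 4.5-fold higher number from compound 2 to compound 3 (0.65 log units; beyond the scatter) and the step of a 2.9-fold lower number from compound 1 to compound 3 (0.46 log units; beyond the scatter) in this assay show that a cyclic group on this sulfur gives a number distinct from both the amino and the 2-hydroxyethyl compounds. Among the three compounds, both hydroxyl-bearing groups give higher numbers than amino, and they still differ from each other beyond the scatter. Nothing available accounts for these differences. Open, on these data alone, is whether the hydroxyl or the ring sets the number of compound 3, which an unsubstituted pyrrolidin-1-yl or a morpholin-4-yl group on the sulfur would help separate.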